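From 4-methylphenyl to 2-fluorophenyl on the carbonyl

This account rests on a few compounds, and the source may have more. Where it says the series, first, only, none or still open, it means among the compounds named here.

Within the data shown here, in a functional assay on SGC-7901 cells (Homo sapiens) for antiproliferative activity, read by MTT assay, with a stated time of 24 h (on this read-out higher numbers stand for weaker inhibition and lower numbers for stronger inhibition), compound 3 `Cc1ccc(C(=O)NNC(=O)c2ccccc2NS(=O)(=O)c2cnc(O)nc2O)cc1` gives 15500 nM, the only actual number so far. Compound 1 `Cc1cccc(NNC(=O)c2ccccc2NS(=O)(=O)c2cnc(O)nc2O)c1` reads > 20000 nM, which is a limit of the assay. Compound 2 `O=C(NNc1ccc(F)cc1)c1ccccc1NS(=O)(=O)c1cnc(O)nc1O` reads > 20000 nM, also a limit. The series therefore shows (the limit of > 20000 nM in this assay, at which 2 of the 3 values shown sit).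

Compound 4 `O=C(NNC(=O)c1ccccc1NS(=O)(=O)c1cnc(O)nc1O)c1ccccc1F` carries 2-fluorophenyl in place of 4-methylphenyl on a carbonyl carbon. Among the measured compounds shown here, no measured step changes a group at this place. The nearest evidence is an at least 1.2-fold lower number from compound 1 to compound 3 (0.11 log units; that floor lies within the scatter) and an at least 1.2-fold lower number from compound 2 to compound 3 (0.11 log units; that floor lies within the scatter), both floors within the scatter, while a step that the two limits leave unreadable from compound 1 to compound 2 gives no usable size. Nothing here supports an expected shift in either direction in this assay, so no step beyond the scatter is expected. The expected change is a 1.0-fold higher number from compound 3 to compound 4 (0.01 log units; within the scatter). For compound 4, a reading reported only as a limit remains quite possible. For compound 4 the estimated value is 16000 nM, with an expected range of 8000 nM to 28000 nM.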

Compound 4, half-maximal inhibitory concentration: > 20000 nM
Compound 4 gave a limit, no number; the forecaster's own chance of this, stated with the estimate: 40%; at least 1.2-fold (0.09 log units) between middle value and limit.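

Among these compounds, the only step read at this carbonyl carbon in this assay is an at least 1.2-fold higher number from compound 3 to compound 4 (0.11 log units; that floor lies within the scatter). On these data alone, compound 4 reads > 20000 nM, which is a limit of the assay, so the true size of this change stays unknown. The steps from compound 1 and from compound 2 to compound 4 cannot be read, and compound 3 remains the only compound with an actual number: the limit of > 20000 nM in this assay, at which 3 of the 4 values shown sit.

As far as these compounds go, how far compound 4 lies from compound 3 remains open, and so does whether any group on this carbonyl carbon can bring the number clearly down. Also open, from the compounds shown here alone, is what an amine, a carboxylic acid or a longer chain in place of 2-fluorophenyl would read at this place.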